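Restoring a carboxy on the terminal amine chain

The source may hold more compounds than are shown below. What is called first, only, known or untested is meant among the compounds shown, and "the series" means these compounds.

Measured compounds:
compound 1 `CCCCCCCCCCCCN[C@H](CCC(=O)NC(CCCC(N)C(=O)O)C(=O)O)C(=O)O` — 0.023 nM
compound 2 `CCCCCCCCCCCOC(=O)[C@H](N)CCC(=O)NC(CCCC(N)C(=O)O)C(=O)O` — 0.066 nM
compound 3 `CCCCCCCCCCCC(=O)N[C@H](CCC(=O)NCCCCCN)C(=O)O` — > 100 nM

Compounds 1 and 2 share the amide-linked amino acid unit that carries two carboxy groups and two amino groups, and both give low values in a functional assay on HEK293 cells for agonist activity at Nucleotide-binding oligomerization domain-containing protein 1 (Homo sapiens), read by spectrophotometry; a higher number here means that more compound is needed for the effect, a lower number that less compound is needed. Compound 3 replaces that unit with a 5-aminopentyl chain on the amide nitrogen. Compound 3 is recorded only as a limit, > 100 nM, and it is one of the values that sits at the limit of > 100 nM in this assay, at which 1 of the 3 values shown sits. Where compound 3 stands is therefore known only as a boundary, not as a number.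

Compound 4 `CCCCCCCCCCCC(=O)N[C@H](CCC(=O)N[C@@H](CCCCN)C(=O)O)C(=O)O` puts back one of the missing groups: carboxy in place of hydrogen on a saturated chain carbon bound to an amide-type nitrogen and a saturated chain carbon. Compound 4 is not yet measured in this assay. He expects compound 4 to be stronger than the boundary shown for compound 3, with the step from compound 3 to compound 4 estimated at an at least 1.6-fold lower number from compound 3 to compound 4 (0.22 log units; that floor lies within the scatter), yet well short of compounds 1 and 2, which keep the second carboxy and amino group that compound 4 still lacks. His estimate for compound 4 is 60 nM, in a range from 5 nM to 500 nM.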

Compound 4, half-maximal effective concentration: 0.57 nM
Estimate against measurement, compound 4: 110-fold (2.02 log units) above; the whole stated range lies above it.
By their numbers in this assay, from the lowest: compound 1; then compound 2; then compound 4. At a limit, above all of these: compound 3.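

In this assay, carboxy in place of hydrogen on a saturated chain carbon bound to an amide-type nitrogen and a saturated chain carbon gives an at least 170-fold lower number from compound 3 to compound 4 (2.24 log units; beyond the scatter). Within the data shown here, compounds 1 and 2 each differ from the others in more than one place, so this is the first reading of a single change, and it shows that this carbon responds strongly to that one group. Compound 3 is a limit and not a number, so the step gives only a floor: the limit of > 100 nM in this assay, at which 1 of the 4 values shown sits.

Going by these compounds, whether a carboxamide or a hydroxymethyl on this same carbon could stand in for the carboxy remains open. Compounds 1 and 2 differ from compound 4 in more than one place, so what each of their differences contributes also stays unresolved.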